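Swapping a Dichlorophenyl for a Methoxyphenyl

The source may hold more compounds than are shown below. What is called first, only, known or untested is meant among the compounds shown, and "the series" means these compounds.

Of the compounds shown here, two have been measured in a functional assay on UACC-257 cells (Homo sapiens) for inhibition, read by sulforhodamine B assay, with a stated time of 48 h; on this read-out lower numbers stand for stronger inhibition of growth and higher numbers for weaker inhibition of growth. Compound 1 `COc1ccc(-c2cc(/C=C/C(=O)c3ccc(N)cc3)[nH]n2)cc1` gives 4210 nM in this assay. Compound 2 `COc1cc(-c2cc(/C=C/C(=O)c3ccc(Cl)c(Cl)c3)[nH]n2)cc(OC)c1OC` gives 74000 nM, the higher of the two numbers, so compound 2 is the weaker growth inhibitor, and this gap lies beyond the usual scatter. Compound 3 `COc1ccc(C(=O)/C=C/c2cc(-c3cc(OC)c(OC)c(OC)c3)n[nH]2)cc1` has not yet been measured. It differs from compound 2 in one place: 4-methoxyphenyl in place of 3,4-dichlorophenyl on a carbonyl carbon. Within the data shown here, no measured pair shows this change directly, so the size of the step is uncertain. A modest move toward stronger inhibition is expected, giving a 2.5-fold lower number from compound 2 to compound 3 (0.39 log units; beyond the scatter). For compound 3 the estimate is 30000 nM, with a range from 8000 nM to 100000 nM.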

Compound 3, concentration for total growth inhibition: 3740 nM
Compound 3: middle estimate off by 8.0-fold (0.90 log units), on the high side; the measured number lies below the stated range.
By their numbers in this assay, from the lowest: compounds 3 and 1 (each within the scatter of the next); then compound 2.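

At this carbonyl carbon, the choice of aromatic group has a large effect in this assay: 4-methoxyphenyl in place of 3,4-dichlorophenyl gives a 20-fold lower number from compound 2 to compound 3 (1.30 log units; beyond the scatter). Among these compounds, since the rest of the molecule is unchanged, this whole step belongs to that one swap, which the earlier compounds could not isolate. Nothing available here explains the size of the step.

From the compounds shown here alone, it remains open whether the gain comes from gaining the methoxy group or losing the chlorines. A plain phenyl or 4-hydroxyphenyl group at this carbon could help separate those two possibilities.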